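The compounds below may be only part of what the source reports. "The series", "measured", "known", "first", "only" and "open" are said of these compounds alone.

Compound 1 `Cn1ncc2c(=O)n(-c3ccccc3)c(COc3cccc(F)c3)nc21` — 8200 nM
Compound 2 `Cn1ncc2c(=O)n(-c3ccccc3)c(SC(C)(C)c3ccccc3)nc21` — 1900 nM
Compound 3 `CC(Sc1nc2nn(C3COC3)cc2c(=O)n1-c1ccccc1)c1ccccn1` — 68 nM

In an assay on isolated protein for inhibition of aldehyde dehydrogenase 1A1 (Homo sapiens) (a lower number here means a stronger inhibitor, a higher number a weaker inhibitor), compound 1 gives the highest of the three numbers. Compound 2 gives 1900 nM in this assay, a lower number than compound 1 by a margin beyond the scatter, and compound 3 gives 68 nM, the furthest from compound 1 and again well beyond the scatter. Compound 1 therefore stands as the weakest inhibitor of the three measured compounds.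

Compound 4 `Cn1ncc2c(=O)n(-c3ccccc3)c(CNc3cccc(F)c3)nc21` has not yet been measured in this assay. It differs from compound 1 in one place: (3-fluorophenyl)amino in place of 3-fluorophenoxy on a saturated chain carbon bound to an aromatic carbon. Among the measured compounds shown here, no pair of measured compounds shows this exchange, so the size of the step from compound 1 cannot be read from any earlier comparison; compounds 2 and 3 differ from compound 1 at other places as well and do not isolate this change. The expectation is a step of modest size, more likely toward a lower number than a higher one, and possibly no step beyond the scatter at all. For compound 4 the estimate in this assay is 5000 nM, with a range from 1500 nM to 20000 nM. The step of a 1.6-fold lower number from compound 1 to compound 4 (0.21 log units; within the scatter) that this estimate implies is expected to be small.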

Compound 4, half-maximal inhibitory concentration in the aldehyde dehydrogenase 1A1 assay: 570 nM
For compound 4 the middle estimate is 8.8-fold (0.94 log units) above the measured one; the measured number lies below the stated range.
By their numbers in the aldehyde dehydrogenase 1A1 assay, from the lowest: compound 3; then compound 4; then compound 2; then compound 1.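

In the aldehyde dehydrogenase 1A1 assay, (3-fluorophenyl)amino in place of 3-fluorophenoxy on a saturated chain carbon bound to an aromatic carbon gives a 14-fold lower number from compound 1 to compound 4 (1.16 log units; beyond the scatter), so this one place has a large bearing on the number, which compound 2 and compound 3 could not show because they differ from compound 1 at other places as well. The two groups have the same count of heavy atoms and the same six-membered aromatic ring of carbon only; nitrogen enters in place of oxygen, together with a hydrogen-bond donor, and this small exchange alone separates the two compounds. In a physicochemical assay for solubility, using the shake flask method, in phosphate buffer, with a stated time of 24 h, at pH 7.4 (on this read-out higher numbers stand for higher solubility and lower numbers for lower solubility), compound 1 gives 194000 nM and compound 4 gives 64000 nM. The exchange also has a measured cost in the physicochemical assay: the measured solubility of compound 1, 194000 nM, and of compound 4, 64000 nM, a 3.0-fold lower number (0.48 log units; beyond the scatter)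

The compounds shown leave open whether the lower number goes with the hydrogen on the nitrogen or with the nitrogen itself, a question that a methylated amine at the same place would address. They also leave open whether an amide or a longer chain there could keep the number seen in the aldehyde dehydrogenase 1A1 assay for compound 4 while giving back the solubility seen for compound 1.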